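The source may hold more compounds than are shown below. What is called first, only, known or untested is meant among the compounds shown, and "the series" means these compounds.

Measured compounds:
- compound 1 `O=C(Nc1cc(C(F)(F)F)cc(C(F)(F)F)c1)c1ccc(Sc2ccc(O)cc2)cc1`: 3350 nM
- compound 2 `O=C(Nc1cc(C(F)(F)F)ccc1C(F)(F)F)c1ccc(Sc2ccc(O)cc2)cc1`: 10300 nM
- compound 3 `O=C(Nc1cc(C(F)(F)F)cc(C(F)(F)F)c1)c1ccc(S(=O)(=O)c2ccc(O)cc2)cc1`: 6440 nM

Of the compounds shown here, three have been measured in a functional assay on CWR22R cells (Homo sapiens) for antiproliferative activity, read by fluorescence and propidium iodide staining, with a stated time of 96 h; on this read-out higher numbers stand for weaker inhibition and lower numbers for stronger inhibition. Compound 1 gives 3350 nM, and compound 3, which carries the change ((4-hydroxyphenyl)sulfonyl in place of (4-hydroxyphenyl)sulfanyl on an aromatic carbon), gives 6440 nM; the step of a 1.9-fold higher number from compound 1 to compound 3 (0.28 log units; within the scatter). Compound 2 gives 10300 nM in this assay, a higher number than compound 1 and one within the scatter of compound 3. The difference between the core of compound 1 and the core of compound 2 is not broken down here.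

Compound 4 `O=C(Nc1cc(C(F)(F)F)ccc1C(F)(F)F)c1ccc(S(=O)(=O)c2ccc(O)cc2)cc1` has not yet been measured. It differs from compound 2 by (4-hydroxyphenyl)sulfonyl in place of (4-hydroxyphenyl)sulfanyl on an aromatic carbon, the same change that leads from compound 1 to compound 3. Because the step of a 1.9-fold higher number from compound 1 to compound 3 (0.28 log units; within the scatter) was small, the expected step from compound 2 to compound 4 is a 1.8-fold higher number from compound 2 to compound 4 (0.27 log units; within the scatter), placed beside the earlier one on the assumption that the change behaves alike on both cores. The estimate for compound 4 in this assay is therefore 19000 nM, with an expected range from 8000 nM to 45000 nM.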

Compound 4, half-maximal inhibitory concentration: 20700 nM
Compound 4: middle estimate off by 1.1-fold (0.04 log units), on the low side, and the stated range covers the measured number.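

In this assay, putting (4-hydroxyphenyl)sulfonyl in place of (4-hydroxyphenyl)sulfanyl on the core of compound 2 gives a 2.0-fold higher number from compound 2 to compound 4 (0.30 log units; within the scatter). Set beside the earlier step, the change reads alike on the two cores: the same change on two cores in this assay, a 1.9-fold higher number (0.28 log units; within the scatter) from compound 1 to compound 3 and a 2.0-fold higher number (0.30 log units; within the scatter) from compound 2 to compound 4, 1.0-fold (0.02 log units) apart, within the scatter of two such steps This shows that the change carried over from one core to the other with no detectable difference in its size, but since each step on its own lies within the scatter, it does not establish that the change alters inhibition at all, and two closely related cores cannot speak for the wider series.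

The compounds shown leave open how the same change behaves on a core in which a nitrile or a chlorine stands in place of trifluoromethyl. They also leave open what an ether oxygen or a sulfinyl group would give as the link, or an amine or a carboxylic acid in place of the hydroxy group.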